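From tert-Butoxycarbonyl to Methylsulfanyl: Compound 3 to Compound 4

A few compounds are considered here, and "the series" means these few. Any claim that something is new, unique, unknown or untested is made for them only; others in the source may bear on it.

Three compounds sharing one core were tested in an ADME assay on PC-3 cells (Homo sapiens) for cytotoxicity, read by WST assay, tested at 100 uM; a higher number here means more inhibition at the concentration tested (going by the name of the read-out), a lower number less inhibition. Compound 1 `O=C(Nc1cccc(-c2ccco2)c1)C1CCCN(C(=O)c2cc(C(F)(F)F)cc(C(F)(F)F)c2)C1` gives 0% there, compound 2 `O=C(Nc1ccc(Cl)cc1)C1CCCN(C(=O)c2cccc(-c3nccs3)c2)C1` gives 32%, and compound 3 `CC(C)(C)OC(=O)c1cccc(NC(=O)C2CCCN(C(=O)c3cc(C(F)(F)F)cc(C(F)(F)F)c3)C2)c1` gives 0%. Compound 3 thus stands level with compound 1 at the low end of the three, while compound 2 shows a higher number. For the measured compounds named here, the one measured step between close relatives, no change at the digits printed from compound 1 to compound 3 (within the scatter), exchanged a group on an aromatic carbon without moving the read-out beyond the scatter. Compound 4 `CSc1cccc(NC(=O)C2CCCN(C(=O)c3cc(C(F)(F)F)cc(C(F)(F)F)c3)C2)c1` is not yet measured; it differs from compound 3 by methylsulfanyl in place of tert-butoxycarbonyl on an aromatic carbon. Going by the values given here, no measured step covers this exact exchange, but since no change at the digits printed from compound 1 to compound 3 (within the scatter) showed no change at the same kind of position, the expected step of a number 4 percentage points higher from compound 3 to compound 4 (within the scatter) is none beyond the scatter. Compound 4 is therefore expected to give 4%, between 0% and 18%.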

Compound 4, a percentage reported as inhibition, at one concentration (the size of the read-out at that concentration, not a potency): 0%
Compound 4: middle estimate off by 4 percentage points, on the high side; measured number inside the range.
By their numbers in this assay, from the lowest: compounds 1, 3 and 4 (each within the scatter of the next); then compound 2.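

In this assay, methylsulfanyl in place of tert-butoxycarbonyl gives no change at the digits printed from compound 3 to compound 4 (within the scatter), and methylsulfanyl in place of furan-2-yl gives no change at the digits printed from compound 1 to compound 4 (within the scatter). Three quite different groups on this aromatic carbon, one of them a ring and one holding sulfur, therefore cannot be told apart by this read-out on the shared core. No measurement shown gives a reason for this sameness. On these data alone, whether an amine or a carboxylic acid on this carbon would move the number remains open.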